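Replacing the Anilino Group of Compound 1

The compounds below may be only part of what the source reports. "The series", "measured", "known", "first", "only" and "open" are said of these compounds alone.

Measured so far:
compound 1 `Nc1ccccc1NC(=O)/C=C/c1ccc(Cn2cnc3c(Nc4ccccc4)nc(Cl)nc32)cc1`: 41.9%
compound 2 `Nc1ccccc1NC(=O)c1ccc(Cn2cnc3c(Nc4ccccc4)nc(Cl)nc32)cc1`: 74.8%
compound 3 `Nc1ccccc1NC(=O)c1ccc(Cn2cnc3c(Nc4cccc(OC(F)(F)F)c4)nc(Cl)nc32)cc1`: 31.2%

In a functional assay on HepG2 cells (Homo sapiens) for antiproliferative activity, read by CCK-8 assay, with a stated time of 72 h, tested at 8 uM (on this read-out higher numbers stand for a stronger effect at the one concentration tested and lower numbers for a weaker effect), compound 1 stands second highest of the three numbers. Two steps are known: a number 32.9 percentage points higher from compound 1 to compound 2 (beyond the scatter), and a number 43.6 percentage points lower from compound 2 to compound 3 (beyond the scatter). Compound 4 `CC1CCN(c2nc(Cl)nc3c2ncn3Cc2ccc(/C=C/C(=O)Nc3ccccc3N)cc2)CC1` differs from compound 1 at another place: 4-methylpiperidin-1-yl in place of anilino on an aromatic carbon. Neither measured step touches this position; one alters the linker to the amide, the other adds a group to the anilino ring. Among the measured compounds shown here, no step therefore bears directly on the exchange, and for compound 4 no change beyond the scatter is expected, with a wide range. Compound 4 is expected to give 38%, between 15% and 62%, an expected step of a number 3.9 percentage points lower from compound 1 to compound 4 (within the scatter).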

Compound 4, a percentage reported as inhibition, at one concentration (the size of the read-out at that concentration, not a potency): 32.2%
Compound 4: the middle estimate sits 5.8 percentage points above what was measured; the range from low to high includes it.
By their numbers in this assay, from the lowest: compounds 3, 4 and 1 (each within the scatter of the next, the first and the last beyond it); then compound 2.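

In this assay, 4-methylpiperidin-1-yl in place of anilino gives a number 9.7 percentage points lower from compound 1 to compound 4 (within the scatter), so this position of compound 1 accepts a non-aromatic ring without a hydrogen-bond donor and shows no clear loss. Here, the aromatic ring and hydrogen-bond donor of anilino are not required for a measurable effect at the one concentration tested. No available measurement explains this result. From the compounds shown here alone, whether the exchange behaves the same way with the shorter linker of compound 2 remains open. So does the outcome with morpholin-4-yl or dimethylamino at this position.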